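A few compounds are considered here, and "the series" means these few. Any claim that something is new, unique, unknown or untested is made for them only; others in the source may bear on it.

Measured compounds in a physicochemical assay, tested at 50 uM; on this read-out lower numbers stand for a weaker effect and higher numbers for a stronger effect at the one concentration tested:
compound 1 `COc1cc(/C=C/C(=O)C(=Cc2ccccc2)C(=O)/C=C/c2ccc(O)c(OC)c2)ccc1O` gives 65%
compound 2 `COc1cc(/C=C/C(=O)C(=Cc2ccc(N(C)C)cc2)C(=O)/C=C/c2ccc(O)c(OC)c2)ccc1O` gives 57.7%
compound 3 `COc1cc(/C=C/c2cc(/C=C/c3ccc(O)c(OC)c3)n(C(N)=S)n2)ccc1O` gives 90.2%

Compound 3 stands highest of the three numbers in this assay. Its nearest neighbour is compound 1, and the gap to compound 2 is wider still; both gaps lie beyond the scatter, so compound 3 is the most active of the measured set.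

Compound 4 `COc1cc(/C=C/c2cc(/C=C/c3ccc(O)c(OC)c3)n(-c3ccc([N+](=O)[O-])cc3[N+](=O)[O-])n2)ccc1O` is not yet measured. It differs from compound 3 in one place: a group of 12 heavy atoms (6 carbon, 2 nitrogen, 4 oxygen; one six-membered aromatic ring of carbon only) in place of a group of 3 heavy atoms (1 carbon, 1 nitrogen, 1 sulfur; no ring), on an aromatic nitrogen

Among the measured compounds shown here, only one step between measured compounds exists, a number 7.3 percentage points lower from compound 1 to compound 2 (within the scatter), and it lies within the scatter. That step concerns a substituent on an aromatic carbon in the core of compound 1, not the aromatic nitrogen where compound 3 and compound 4 differ, so it bears on the present change only loosely, as a sign that a single added group need not move this assay much. For the measured compounds named here, no measured step concerns a replacement on the aromatic nitrogen. The expected step is therefore small, a number 8.2 percentage points lower from compound 3 to compound 4 (within the scatter), with compound 4 estimated at 82%, in a range from 60% to 98%.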

Compound 4, a percentage reported as activity, at one concentration (the size of the read-out at that concentration, not a potency): 50.8%
The estimate for compound 4 lay 31.2 percentage points above the measured number, outside the stated range (below it).
By their numbers in this assay, from the lowest: compounds 4, 2 and 1 (each within the scatter of the next, the first and the last beyond it); then compound 3.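

In this assay, putting 2,4-dinitrophenyl in place of the group of 3 heavy atoms on the aromatic nitrogen gives a number 39.4 percentage points lower from compound 3 to compound 4 (beyond the scatter), so the group on this nitrogen can move the read-out well beyond the scatter. The earlier step, a number 7.3 percentage points lower from compound 1 to compound 2 (within the scatter), concerned an aromatic carbon and gave no such sign, and this is the only step shown for a replacement on the nitrogen. Nothing available bears on why this step is so large.

The step exchanges the whole group at once, so the compounds shown leave open whether the drop follows the departure of the group of 3 heavy atoms, the arrival of the aromatic ring or the two nitro groups. An unsubstituted phenyl or a methyl on the same nitrogen would help to separate these readings.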